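A few compounds are considered here, and "the series" means these few. Any claim that something is new, unique, unknown or untested is made for them only; others in the source may bear on it.

Measured compounds in the series:
- compound 1, `NS(=O)(=O)CC(=O)NCCSc1nonc1/C(=N/O)Nc1cccc(Cl)c1`, 10 nM
- compound 2, `NS(=O)(=O)CC(=O)NCCSc1nonc1/C(=N/O)Nc1ccc(F)c(C(F)F)c1`, 13 nM
- compound 3, `CC1(C(=O)NCCSc2nonc2/C(=N/O)Nc2ccc(F)c(C(F)F)c2)CCN1`, 16 nM

All three values come from an assay for inhibition of Indoleamine 2,3-dioxygenase 1 (Homo sapiens), read by fluorescence, with a stated time of 24 h; on this read-out higher numbers stand for weaker inhibition and lower numbers for stronger inhibition. Compound 3 carries the highest of the three numbers, but the step of a 1.2-fold higher number from compound 2 to compound 3 (0.09 log units; within the scatter) lies within the scatter, and so does the gap between compound 1 and compound 3, so on these numbers the three compounds are not separable.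

Compound 4, `O=C(NCCSc1nonc1/C(=N/O)Nc1ccc(F)c(C(F)F)c1)C1CS(=O)(=O)C1`, is the next step from compound 3. The change is a group of 6 heavy atoms (3 carbon, 2 oxygen, 1 sulfur; one four-membered non-aromatic ring with 1 hetero atom) in place of a group of 5 heavy atoms (4 carbon, 1 nitrogen; one four-membered non-aromatic ring with 1 hetero atom), on a carbonyl carbon. This is the same position that was altered between compound 2 and compound 3, where a 1.2-fold higher number from compound 2 to compound 3 (0.09 log units; within the scatter); the other measured step, a 1.3-fold higher number from compound 1 to compound 2 (0.11 log units; within the scatter), concerns the group on the amine nitrogen and does not bear on this position. Going by the values given here, both measured steps sit within the scatter, so the series so far gives no sign that the group on this carbonyl carbon shifts the read-out in this assay by more than the scatter. For compound 4 a step of a 1.1-fold higher number from compound 3 to compound 4 (0.05 log units; within the scatter) is therefore expected, with no direction that can be defended beyond the scatter. Compound 4 is estimated at 18 nM, with a range from 8 nM to 40 nM.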

Compound 4, half-maximal inhibitory concentration: 13 nM
The estimate for compound 4 lay 1.4-fold (0.14 log units) above the measured number; the measured number falls inside the stated range.
By their numbers in this assay, from the lowest: compounds 1, 2, 4 and 3 (each within the scatter of the next).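

Working notes on the carbonyl carbon: in this assay, the exchange of one four-membered non-aromatic ring group for another gives a 1.2-fold lower number from compound 3 to compound 4 (0.09 log units; within the scatter), so the series now shows that a group with 0 hydrogen-bond donors and 2 hydrogen-bond acceptors can replace one with 1 hydrogen-bond donor and 1 hydrogen-bond acceptor without a step beyond the scatter. Set against the group with no ring, the same ring group gives no change at the digits printed from compound 2 to compound 4 (within the scatter), which places three different groups on this carbonyl carbon, one with no ring and two with a four-membered non-aromatic ring, within the scatter of each other. No supporting evidence is available that would explain this result.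

Still open, on these data alone, is whether a carboxylic acid, a primary amine or a longer alkyl chain on this carbonyl carbon would move the read-out beyond the scatter. Going by these compounds alone, both four-membered ring groups are also seen only with the 3-(difluoromethyl)-4-fluorophenyl group on the amine nitrogen, so their behaviour with the 3-chlorophenyl group remains an open question.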